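The compounds below may be only part of what the source reports. "The series", "measured", "known", "first", "only" and "open" are said of these compounds alone.

Measured compounds:
Compound 1, `Cc1ccc(Cn2cc(CNC(=O)c3cnc(Nc4ccc(C#N)cc4)cc3Oc3c(C)cc(C)cc3C)nn2)cc1`: 165000 nM in an ADME assay on MT4 cells (Homo sapiens) for cytotoxicity, read by MTT assay, with a stated time of 5 days; on this read-out higher numbers stand for lower toxicity in this test and lower numbers for higher toxicity in this test.
Compound 2, `Cc1cc(C)c(Oc2cc(Nc3ccc(C#N)cc3)ncc2C(=O)NCc2cn(Cc3ccc(F)cc3)nn2)c(C)c1`: in this assay compound 2 gives >= 153000 nM, which is a limit of the assay rather than a number.

Compound 2 therefore stands at the limit of >= 153000 nM in this assay, at which 1 of the 2 values shown sits. Among the compounds with values here, the one measured step, a step that the limit leaves unreadable from compound 1 to compound 2, cannot be read for size, so it gives no scale for any change. Compound 3, `Cc1cc(C)c(Oc2cc(Nc3ccc(C#N)cc3)ncc2C(=O)NCc2cn(CC(=O)N3CCCC3)nn2)c(C)c1`, differs from compound 2 in one place: (pyrrolidin-1-yl)carbonyl in place of 4-fluorophenyl on a saturated chain carbon bound to an aromatic nitrogen. Within the data shown here, no measured step covers this kind of change, and the only step recorded is unreadable, so there is no ground for expecting a step in either direction beyond the scatter; the numbers for compound 1 and compound 2 both sit in the same high region. Compound 3 is expected to give about 160000 nM in this assay, within a range from 60000 nM to 300000 nM. The step from compound 2 to compound 3 is thus estimated as a step that the limit leaves unreadable from compound 2 to compound 3.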

Compound 3, half-maximal cytotoxic concentration: 58100 nM
Compound 3: middle estimate off by 2.8-fold (0.44 log units), on the high side, and the stated range ends above it.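

In this assay, this saturated chain carbon bound to an aromatic nitrogen now gives its first readable steps: (pyrrolidin-1-yl)carbonyl in place of 4-methylphenyl gives a 2.8-fold lower number from compound 1 to compound 3 (0.45 log units; beyond the scatter), and in place of 4-fluorophenyl it gives an at least 2.6-fold lower number from compound 2 to compound 3 (0.42 log units; beyond the scatter). Compound 2 stands at a limit of the assay rather than at a number: the limit of >= 153000 nM in this assay, at which 1 of the 3 values shown sits. The lower number for compound 3 means higher toxicity in this test, so the group at this position can change the read-out, while the step between the two aromatic groups cannot be read.

Going by these compounds, whether the carbonyl or the pyrrolidine ring matters more remains open. So does what a carboxylic acid, a simple amine or a longer chain at this place would give in this assay.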